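Removing the 3-chlorobenzyl group from compound 3

The source may report more compounds than this note shows. Statements on the series, on what has been measured and on what is new or still open speak of the compounds shown alone.

In a functional assay on A549 cells (Homo sapiens) for cytotoxicity, read by MTT assay, with a stated time of 72 h (on this read-out higher numbers stand for weaker inhibition and lower numbers for stronger inhibition), compound 1 `CCN(CC)Cc1ccc2nc(NC(=O)N/N=C/c3cn(Cc4ccc(C(C)(C)C)cc4)c4ccccc34)sc2c1` gives 1710 nM, compound 2 `CC1CCN(Cc2ccc3nc(NC(=O)N/N=C/c4cn(Cc5ccc(Cl)cc5Cl)c5ccccc45)sc3c2)CC1` gives 3640 nM and compound 3 `CC1CCN(Cc2ccc3nc(NC(=O)N/N=C/c4cn(Cc5cccc(Cl)c5)c5ccccc45)sc3c2)CC1` gives 2810 nM. Compound 3 therefore lies within the scatter of both others. Compound 4 `CC1CCN(Cc2ccc3nc(NC(=O)N/N=C/c4c[nH]c5ccccc45)sc3c2)CC1` has hydrogen in place of 3-chlorobenzyl on an aromatic nitrogen. For the measured compounds named here, the only measured step, a 1.3-fold lower number from compound 2 to compound 3 (0.11 log units; within the scatter), stays within the scatter, but it merely swaps 2,4-dichlorophenyl for 3-chlorophenyl. Going by the values given here, no measured compound lacks the whole group, so this step sets no firm size for the new change. A move toward weaker inhibition is expected, estimated as a 3.2-fold higher number from compound 3 to compound 4 (0.51 log units; beyond the scatter). For compound 4 the expected value is 9000 nM, with an estimated range from 3000 nM to 30000 nM.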

Compound 4, half-maximal inhibitory concentration: 3580 nM
Beside the measured number, compound 4's estimate is 2.5-fold (0.40 log units) above it; low and high end bracket the measured number.
By their numbers in this assay, from the lowest: compounds 1, 3, 4 and 2 (each within the scatter of the next, the first and the last beyond it).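

In this assay, replacing the whole benzyl group on the aromatic nitrogen with hydrogen gives a 1.3-fold higher number from compound 3 to compound 4 (0.11 log units; within the scatter) and a 1.0-fold lower number from compound 2 to compound 4 (0.01 log units; within the scatter), both within the scatter. Compound 4 shows that, in this read-out, a plain hydrogen at this position reads the same as either chlorinated benzyl group, so the ring and its chlorines are not needed to keep this level of cytotoxicity. No evidence here explains this result. Still open, as far as these compounds go, is whether a methyl group, or a longer chain ending in an amine, on this nitrogen would also stay within the scatter.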